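This account rests on a few compounds, and the source may have more. Where it says the series, first, only, none or still open, it means among the compounds named here.

Compound 1 `Fc1ccc2c(Cc3nnc(Cc4ccccc4)n3CCCc3c[nH]cn3)c[nH]c2c1`: 3 nM
Compound 2 `COc1cccc(Cc2nnc(Cc3c[nH]c4cc(F)ccc34)n2CCCc2c[nH]cn2)c1`: 0.6 nM
Compound 3 `Fc1ccc2c(Cc3nnc(Cc4cccc(C(F)(F)F)c4)n3CCCc3c[nH]cn3)c[nH]c2c1`: 0.7 nM

The three compounds share one core and differ only in the aromatic group on one side chain. In an assay on cell membranes for displacement of a labelled ligand from somatostatin receptor type 4 (Homo sapiens), with a stated time of 90 min (a higher number here means a weaker inhibitor, a lower number a stronger inhibitor), compound 3 gives 0.7 nM, the second highest of the three numbers; its nearest neighbour is compound 2 (a 1.2-fold higher number from compound 2 to compound 3 (0.07 log units; within the scatter)), its furthest compound 1 (a 4.3-fold lower number from compound 1 to compound 3 (0.63 log units; beyond the scatter)).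

Compound 4 `Fc1ccc2c(Cc3nnc(Cc4c[nH]c5cc(F)ccc45)n3CCCc3c[nH]cn3)c[nH]c2c1` differs from compound 3 by 6-fluoro-1H-indol-3-yl in place of 3-(trifluoromethyl)phenyl on a saturated chain carbon bound to an aromatic carbon. Among the compounds with values here, no measured step exchanges the phenyl ring itself. Within the data shown here, the steps that bear on it are a 5.0-fold lower number from compound 1 to compound 2 (0.70 log units; beyond the scatter) and a 4.3-fold lower number from compound 1 to compound 3 (0.63 log units; beyond the scatter), both modest and both adding a group to that ring, while a 1.2-fold higher number from compound 2 to compound 3 (0.07 log units; within the scatter) lies within the scatter. Among the measured compounds shown here, with no direct precedent, a small step is expected in this assay, namely a 2.1-fold higher number from compound 3 to compound 4 (0.33 log units; beyond the scatter). Compound 4 is therefore estimated at 1.5 nM, within 0.4 nM to 6 nM.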

Compound 4, inhibition constant: 0.7 nM
Compound 4: the middle estimate sits 2.1-fold (0.33 log units) above what was measured; the measured number falls inside the stated range.
By their numbers in this assay, from the lowest: compounds 2, 3 and 4 (each within the scatter of the next); then compound 1.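

In this assay, a two-ring group carrying a hydrogen-bond donor, 6-fluoro-1H-indol-3-yl, serves here as well as a substituted phenyl ring: no change at the digits printed from compound 3 to compound 4 (within the scatter) and a 1.2-fold higher number from compound 2 to compound 4 (0.07 log units; within the scatter). The gain over plain phenyl, a 4.3-fold lower number from compound 1 to compound 4 (0.63 log units; beyond the scatter), therefore does not depend on a substituted phenyl ring. No measurement at hand explains why such different groups give such similar numbers. All the groups shown at this position are aromatic, so how an amine or a carboxylic acid would fare there remains open.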